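Replacing an Ethyl Amide with a Benzylidene Hydrazide

The compounds below may be only part of what the source reports. "The series", "measured", "known", "first", "only" and "open" are said of these compounds alone.

Compound 1 `CCNC(=O)c1oc2nc(-c3ccccc3)cc(C(F)(F)F)c2c1N` is tested in a functional assay on HepG2 cells (Homo sapiens) for antiproliferative activity, read by MTT assay (a lower number here means a stronger inhibitor, a higher number a weaker inhibitor), where compound 1 gives 42800 nM. That is the highest of the three numbers measured here. The nearest is compound 3 `Nc1c(C(=O)N/N=C/c2ccccc2)oc2nc(-c3cccs3)cc(C(F)(F)F)c12`, which in this assay gives 9900 nM, and the furthest is compound 2 `Nc1c(C(=O)N/N=C/c2ccc(Br)cc2)oc2nc(-c3cccs3)cc(C(F)(F)F)c12`, which in this assay gives 6100 nM. Going by the values given here, the only step between two compounds differing in one place is a 1.6-fold higher number from compound 2 to compound 3 (0.21 log units; within the scatter), which concerns a bromo group on the aromatic ring and not the amide nitrogen.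

Compound 4 `Cc1ccc(/C=N/NC(=O)c2oc3nc(-c4ccccc4)cc(C(F)(F)F)c3c2N)cc1` differs from compound 1 by a group of 9 heavy atoms (8 carbon, 1 nitrogen; one six-membered aromatic ring of carbon only) in place of a group of 2 heavy atoms (2 carbon; no ring), on an amide-type nitrogen. Among the compounds with values here, no measured step covers this change directly: compounds 2 and 3 carry a similar group on the amide nitrogen, but they also differ from compound 1 in the ring attached to the shared core, so their lower numbers are only a loose guide. On that guide, a lower number is expected for compound 4, with a step of about a 4.3-fold lower number from compound 1 to compound 4 (0.63 log units; beyond the scatter). The estimate for compound 4 in this assay is 10000 nM, with a range from 3000 nM to 35000 nM.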

Compound 4, half-maximal inhibitory concentration: 8900 nM
For compound 4 the middle estimate is 1.1-fold (0.05 log units) above the measured one, within the range that was stated.
By their numbers in this assay, from the lowest: compounds 2, 4 and 3 (each within the scatter of the next); then compound 1.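

In this assay, going by these compounds alone, the change on the amide-type nitrogen gives a 4.8-fold lower number from compound 1 to compound 4 (0.68 log units; beyond the scatter), and this is the first reading of that change with the ring attached to the shared core held the same. The earlier compounds shown here could only hint at this, as they differed from compound 1 in that ring as well as on the amide nitrogen. Nothing shown here offers a measured reason for the step.

The entering group brings in an aromatic ring and a double bond together, so the compounds shown do not tell which part accounts for the lower number. A plain benzyl group or a longer chain such as butyl on the same nitrogen would help to separate the contribution of the ring from that of the link holding it.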